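The source may report more compounds than this note shows. Statements on the series, on what has been measured and on what is new or still open speak of the compounds shown alone.

Working notes on the series, following the step from compound 1 `C/C(=C\CC/C(C)=C/CC[C@@H]1[C@@]2(C)CCC(=O)C(C)(C)[C@H]2CC[C@@]1(C)O)CC/C=C(\C)C(=O)OCc1cn(-c2ccc(F)c(Cl)c2)nn1` to compound 4 `C/C(=C\CC/C(C)=C/CC[C@@H]1[C@@]2(C)CCC(=O)C(C)(C)[C@H]2CC[C@@]1(C)O)CC/C=C(\C)C(=O)OCc1cn(-c2ccccc2)nn1`. In an ADME assay on L132 cells (Homo sapiens) for cytotoxicity, read by MTT assay, with a stated time of 48 h (a higher number here means a weaker inhibitor, a lower number a stronger inhibitor), compound 1 gives > 150000 nM, which is a limit of the assay and not a number. Compound 3 `C/C(=C\CC/C(C)=C/CC[C@@H]1[C@@]2(C)CCC(=O)C(C)(C)[C@H]2CC[C@@]1(C)O)CC/C=C(\C)C(=O)OCc1cn(-c2ccccc2C)nn1` gives > 150000 nM, and this too is a limit. Among the measured compounds shown here, compound 2 `C/C(=C\CC/C(C)=C/CC[C@@H]1[C@@]2(C)CCC(=O)C(C)(C)[C@H]2CC[C@@]1(C)O)CC/C=C(\C)C(=O)OCc1cn(C[C@@H]2O[C@H](n3ccc(=O)[nH]c3=O)C[C@H]2O)nn1` gives 148000 nM, the only true number in the set. The overall picture is the limit of > 150000 nM in this assay, at which 2 of the 3 values shown sit, so compound 1 stands at the limit and cannot be placed more exactly.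

Compound 4 keeps the core of compound 1 and carries phenyl in place of 3-chloro-4-fluorophenyl on an aromatic nitrogen of the five-membered aromatic ring with 3 nitrogen: phenyl in place of 3-chloro-4-fluorophenyl on an aromatic nitrogen.

For the measured compounds named here, the one measured step at this nitrogen with an aryl group entering is a step that the two limits leave unreadable from compound 1 to compound 3, where 2-methylphenyl replaces 3-chloro-4-fluorophenyl. It gives a precedent of a kind, but no size and no direction. Going by the values given here, with that as the only guide, no change beyond the scatter is expected in this assay, and a second reading at the limit is the likeliest outcome. The expected step is a number no higher from compound 1 to compound 4 (the limit leaves the size open). The estimated value for compound 4 is 150000 nM, with an expected range of 80000 nM to 300000 nM.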

Compound 4, half-maximal inhibitory concentration: > 150000 nM
Compound 4 gave a limit, no number; the forecaster's own chance of this, stated with the estimate: 75%; the middle value sits exactly at the limit.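

No new step can be read: compound 4, like compound 1 and compound 3, returns only a limit of the assay, so the steps among them stay unreadable. The compounds shown leave open whether phenyl, 2-methylphenyl and 3-chloro-4-fluorophenyl on the aromatic nitrogen differ at all in this assay. The series rests at: the limit of > 150000 nM in this assay, at which 3 of the 4 values shown sit.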